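A few compounds are considered here, and "the series" means these few. Any claim that something is new, unique, unknown or untested is made for them only; others in the source may bear on it.

Measured compounds in the series:

compound 1, `Cc1cc(S(=O)(=O)/N=C(\N)n2nccc2-c2ccccc2)c(SCc2cccc(Cl)c2)cc1Cl`: 88000 nM
compound 2, `Cc1cccc(CSc2cc(Cl)c(C)cc2S(=O)(=O)/N=C(\N)n2nc(C)cc2-c2ccccc2)c1`: 105000 nM

In a functional assay on MCF7 cells (Homo sapiens) for cytotoxicity, read by MTT assay, with a stated time of 72 h (on this read-out lower numbers stand for stronger inhibition and higher numbers for weaker inhibition), compound 1 gives 88000 nM, the lower of the two numbers measured. In this assay compound 2 gives 105000 nM; the gap between compound 1 and compound 2 is within the usual scatter, so the two numbers cannot be told apart and no order between them is claimed. Both values sit far up the concentration range, so the series as measured is weakly cytotoxic.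

Compound 3, `Cc1cc(S(=O)(=O)/N=C(\N)n2nccc2-c2ccccc2)c(SCc2cccc(C(F)(F)F)c2)cc1Cl`, is not yet measured. It differs from compound 1 in one place: trifluoromethyl in place of chloro on an aromatic carbon of the (3-chlorobenzyl)sulfanyl group, which becomes (3-(trifluoromethyl)benzyl)sulfanyl. For the measured compounds named here, no measured pair shows this change, so its size in this assay is unknown and must be judged from compound 1 alone. The expected step from compound 1 to compound 3 is a 1.1-fold lower number from compound 1 to compound 3 (0.04 log units; within the scatter), with no movement beyond the scatter in either direction anticipated. On that basis compound 3 is estimated at 80000 nM in this assay, with a range from 35000 nM to 200000 nM.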

Compound 3, half-maximal inhibitory concentration: 17000 nM
Compound 3: middle estimate off by 4.7-fold (0.67 log units), on the high side; measured number outside the range, below it.
By their numbers in this assay, from the lowest: compound 3; then compounds 1 and 2 (each within the scatter of the next).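

In this assay, trifluoromethyl in place of chloro on the aromatic carbon of the benzyl group gives a 5.2-fold lower number from compound 1 to compound 3 (0.71 log units; beyond the scatter) and so shows that the read-out responds to a change at this single place. The values of compound 1 and compound 2 could not show this, as those two compounds differ in more than one place and their numbers lie within the scatter of each other. This remains one pair on one core, with compound 3 at 17000 nM in this assay, and no measurement shown here gives a reason for the step.

The compounds shown leave open whether the same exchange would give a step of similar size on the core of compound 2, and so whether the step depends on the rest of the molecule. They also leave open how this position responds to other groups, such as bromo, methoxy, a nitrile, an amine or a carboxylic acid, and whether any of these would bring the number lower than that of compound 3.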